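The compounds below may be only part of what the source reports. "The series", "measured", "known", "first", "only" and "open" are said of these compounds alone.

Working notes on the series in an assay on cells for inhibition of cytochrome P450 11B2, mitochondrial (Homo sapiens), read by HTRF; on this read-out higher numbers stand for weaker inhibition and lower numbers for stronger inhibition.

Compound 1 `CCC1c2cc(Cl)ccc2C(=O)N1c1cccnc1` and compound 2 `CC1c2cc(Cl)ccc2C(=O)N1c1cccnc1` share one core. In this assay compound 1 gives 121 nM and compound 2 gives 123 nM. Their only difference is methyl in place of hydrogen on a saturated chain carbon bound to a saturated ring carbon, and the step is a 1.0-fold lower number from compound 2 to compound 1 (0.01 log units; within the scatter), so the two numbers are read as the same.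

Compound 3 `CC1(C)c2cc(Cl)ccc2C(=O)N1c1cncc(CNS(C)(=O)=O)c1` carries a different core and gives 33 nM in this assay, the lowest of the three numbers; its distance to compound 1 and to compound 2 lies beyond the scatter. The difference between the core of compound 3 and the core of compound 2 is not broken down here.

Compound 4 `C[C@@H](NS(C)(=O)=O)c1cncc(N2C(=O)c3ccc(Cl)cc3C2(C)C)c1` is built from compound 3 by methyl in place of hydrogen on a saturated chain carbon bound to an aromatic carbon and a sulfonamide nitrogen. This is the same kind of change as from compound 2 to compound 1, not the same one: there the place was a saturated chain carbon bound to a saturated ring carbon, here it is a saturated chain carbon bound to an aromatic carbon and a sulfonamide nitrogen. Within the data shown here, the one measured example of this kind of change is flat, so a step near a 1.1-fold lower number from compound 3 to compound 4 (0.04 log units; within the scatter) is expected from compound 3 to compound 4, resting on the flat a 1.0-fold lower number from compound 2 to compound 1 (0.01 log units; within the scatter). Compound 4 is therefore estimated at 30 nM, between 12 nM and 75 nM.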

Compound 4, half-maximal inhibitory concentration: 8 nM
Beside the measured number, compound 4's estimate is 3.8-fold (0.57 log units) above it, and the stated range ends above it.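

Methyl in place of hydrogen on a saturated chain carbon bound to an aromatic carbon and a sulfonamide nitrogen gives a 4.1-fold lower number from compound 3 to compound 4 (0.62 log units; beyond the scatter) in this assay. Set beside the earlier step, this kind of change does not carry over from one core to the other with a constant size: the same change on two cores in this assay, a 1.0-fold lower number (0.01 log units; within the scatter) from compound 2 to compound 1 and a 4.1-fold lower number (0.62 log units; beyond the scatter) from compound 3 to compound 4, 4.1-fold (0.61 log units) apart, beyond the scatter of two such steps

This comparison rests on a single pair for each core, and the place of the methyl differs along with the core, so the data do not separate the role of the core from that of the place and do not show how the change behaves on any further core.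

Going by these compounds, it remains open whether a propyl chain or a hydroxymethyl group on the same saturated chain carbon would give a step like that of methyl. On these data alone, the number for the mirror-image form of compound 4 also remains open, so it cannot be said how far the step depends on the arrangement at that carbon.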